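Swapping a Methylphenyl for an Indole on a Potent Compound

The source may hold more compounds than are shown below. What is called first, only, known or untested is meant among the compounds shown, and "the series" means these compounds.

Among the compounds with values here, only two compounds have been tested so far. In a functional assay on HeLa cells (Homo sapiens) for inhibition, read by CCK-8 assay, with a stated time of 48 h (on this read-out lower numbers stand for stronger inhibition and higher numbers for weaker inhibition), compound 1 `COc1cc(-c2cc3nccc(-c4cc(OC)c(OC)c(OC)c4)n3n2)cc(OC)c1OC` reads > 10000 nM, which is a limit of the assay and not a number. Within the data shown here, compound 2 `COc1cc(-c2ccnc3cc(-c4ccc(C)cc4)nn23)cc(OC)c1OC` gives 21 nM in this assay, so it holds the only true number available and has no measured neighbour to be ranked against.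

Compound 3 `COc1cc(-c2ccnc3cc(-c4ccc5cc[nH]c5c4)nn23)cc(OC)c1OC` keeps the core of compound 2 but carries 1H-indol-6-yl in place of 4-methylphenyl on an aromatic carbon. Both groups contain a six-membered aromatic ring of carbon only. Among the measured compounds shown here, no measured pair shows what such a swap does, so any forecast is loose. The expected change, a 1.7-fold higher number from compound 2 to compound 3 (0.22 log units; within the scatter), is small, leaning towards slightly weaker inhibition and probably within the usual scatter. For compound 3 the estimated value is 35 nM, with an expected range from 8 nM to 200 nM.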

Compound 3, half-maximal inhibitory concentration: 125 nM
Estimate against measurement, compound 3: 3.6-fold (0.55 log units) below, within the range that was stated.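

Within the data shown here, this is the first measured change at this position, an aromatic carbon of the five-membered ring with 2 nitrogen. In this assay, putting 1H-indol-6-yl in place of 4-methylphenyl gives a 6.0-fold higher number from compound 2 to compound 3 (0.77 log units; beyond the scatter), so inhibition here does depend on which group sits at this place, and 4-methylphenyl is the better of the two groups measured. Even so, compound 3 still gives a true number, whereas compound 1 alone sits at a limit, which is not a number: the limit of > 10000 nM in this assay, at which 1 of the 3 values shown sits.

A single swap cannot separate what the added five-membered ring does from what its hydrogen-bond donor does, since both enter together. On these data alone, how a simple phenyl, a 4-aminophenyl or a 4-carboxyphenyl would read at this position remains open.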